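Cytotoxicity notes on compounds 1 to 3

The source may report more compounds than this note shows. Statements on the series, on what has been measured and on what is new or still open speak of the compounds shown alone.

Measured so far:
Compound 1 `CN(C)c1ccc2sc(-c3c(Cl)nc(N)nc3N[C@@H]3C[C@H](CO)[C@@H](O)[C@H]3O)nc2c1`: 25000 nM
Compound 2 `CNc1nc(C)c(-c2nc3ccccc3s2)c(N[C@@H]2C[C@H](CO)[C@@H](O)[C@H]2O)n1`: > 25000 nM

In an ADME assay on cells (Homo sapiens) for cytotoxicity, read by polymerase chain reaction, with a stated time of 3 days (on this read-out lower numbers stand for higher toxicity in this test and higher numbers for lower toxicity in this test), compound 1 gives 25000 nM. For compound 2 the reading is a limit of the assay, > 25000 nM. Compound 2 therefore sits at the limit of > 25000 nM in this assay, at which 1 of the 2 values shown sits. Among the measured compounds shown here, no step between measured compounds is available here.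

Compound 3 `Cc1nc(NCc2ccccn2)nc(N[C@@H]2C[C@H](CO)[C@@H](O)[C@H]2O)c1-c1nc2ccccc2s1` differs from compound 2 in pyridin-2-yl in place of hydrogen on a saturated chain carbon bound to a nitrogen on an aromatic ring. The step is expected to be none beyond the scatter, a step that the limit leaves unreadable from compound 2 to compound 3. Compound 3 is estimated at 30000 nM, within 15000 nM to 80000 nM, and a further limit reading is considered likely.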

Compound 3, half-maximal cytotoxic concentration: 13000 nM
For compound 3 the middle estimate is 2.3-fold (0.36 log units) above the measured one; measured number outside the range, below it.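

At the saturated chain carbon bound to a nitrogen on an aromatic ring, pyridin-2-yl in place of hydrogen gives a reading inside the range of this assay: compound 3 gives 13000 nM. Compound 2 stands at a limit of the assay: the limit of > 25000 nM in this assay, at which 1 of the 3 values shown sits. The change gives an at least 1.9-fold lower number from compound 2 to compound 3 (0.28 log units; that floor lies within the scatter), so it is not shown to move the number beyond the scatter, and its true size stays unreadable.

On these data alone, how phenyl or a carboxylic acid on that carbon would read in this assay remains open. As far as these compounds go, whether the ring nitrogen of pyridin-2-yl matters to the number also remains open.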